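Adding a Hydroxyl to the Methoxyphenyl Arm

This account rests on a few compounds, and the source may have more. Where it says the series, first, only, none or still open, it means among the compounds named here.

Measured so far:
Compound 1, `COc1cccc(-c2cc(-c3cc(C(C)C)c(O)cc3C)[nH]c(=O)c2C#N)c1` — 38%
Compound 2, `COc1ccc(-c2cc(-c3cc(C(C)C)c(O)cc3C)[nH]c(=O)c2C#N)cc1` — 43%

In a functional assay for inhibition, tested at 60 ug/mL (on this read-out lower numbers stand for a weaker effect and higher numbers for a stronger effect at the one concentration tested), compound 1 gives 38% and compound 2 gives 43%. Going by the values given here, the only step measured, a number 5 percentage points higher from compound 1 to compound 2 (within the scatter), moves the methoxy group around the phenyl ring and lands within the scatter. Compound 2 therefore stands at the higher of the two numbers, but its step to compound 1 does not separate the two compounds.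

The unmeasured compound 3, `COc1cc(-c2cc(-c3cc(C(C)C)c(O)cc3C)[nH]c(=O)c2C#N)ccc1O`, keeps the core of compound 2 and changes the phenyl arm: 4-hydroxy-3-methoxyphenyl in place of 4-methoxyphenyl on an aromatic carbon. Among the compounds with values here, no measured step covers the addition of a hydroxyl to this ring; the single step in hand concerns only the position of the methoxy group, and it was small. With nothing pointing in either direction, the expected step of a number 1 percentage points higher from compound 2 to compound 3 (within the scatter) is none beyond the scatter, and the estimate leans on the number of compound 2. Compound 3 is therefore expected to give about 44% in this assay, within a range of 24% to 64%.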

Compound 3, a percentage reported as inhibition, at one concentration (the size of the read-out at that concentration, not a potency): 37.5%
Estimate against measurement, compound 3: 6.5 percentage points above; the measured number falls inside the stated range.
By their numbers in this assay, from the lowest: compounds 3, 1 and 2 (each within the scatter of the next).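

In this assay, 4-hydroxy-3-methoxyphenyl in place of 4-methoxyphenyl, on the aromatic carbon ortho to a cyano group and opposite the ring nitrogen, gives a number 5.5 percentage points lower from compound 2 to compound 3 (within the scatter) and thus no separation between the two compounds. The closer comparison, hydroxy in place of hydrogen on an aromatic carbon of the 3-methoxyphenyl arm, gives a number 0.5 percentage points lower from compound 1 to compound 3 (within the scatter) and shows that, in these compounds, adding a hydrogen-bond donor to this arm leaves the read-out within the scatter, just as moving the methoxy group did earlier. Nothing available explains why these compounds stay so close together.

As far as these compounds go, what remains open is whether any group at this position can separate itself from these three compounds, for example an amine or a carboxylic acid on the phenyl arm, or a longer chain such as ethoxy in place of methoxy. Since each compound is read at a single concentration, the numbers also leave open how the size of the effect would compare at other concentrations.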